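Ester to acid on the shared core of compound 3

A few compounds are considered here, and "the series" means these few. Any claim that something is new, unique, unknown or untested is made for them only; others in the source may bear on it.

compound 1 `CCOC(=O)c1sc(-c2cccc(NC(=O)c3ccc(Cl)cc3)c2)nc1Nc1ccc(N2CCN(C)CC2)cc1`: 46.9%
compound 2 `CCOC(=O)c1sc(-c2cccc(NC(=O)c3ccc(C#N)cc3)c2)nc1Nc1ccc(N2CCN(C)CC2)cc1`: 97.5%
compound 3 `CCOC(=O)c1sc(-c2cccc(NC(=O)c3ccc(F)c(Cl)c3)c2)nc1Nc1ccc(N2CCN(C)CC2)cc1`: 72.5%

All three were run in a functional assay on Ramos cells (Homo sapiens) for antiproliferative activity, read by CCK-8 assay, with a stated time of 72 h, tested at 40 uM; a higher number here means more inhibition at the concentration tested (going by the name of the read-out), a lower number less inhibition. Compound 3 stands second highest of the three numbers: it sits beyond the scatter on either side, with a number 25 percentage points lower from compound 2 to compound 3 (beyond the scatter) and a number 25.6 percentage points higher from compound 1 to compound 3 (beyond the scatter). The remaining measured step, a number 50.6 percentage points higher from compound 1 to compound 2 (beyond the scatter), arises from cyano in place of chloro on an aromatic carbon.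

Compound 4 `CN1CCN(c2ccc(Nc3nc(-c4cccc(NC(=O)c5ccc(F)c(Cl)c5)c4)sc3C(=O)O)cc2)CC1` has not yet been measured in this assay. It differs from compound 3 by hydrogen in place of ethyl on an oxygen next to a carbonyl group; read one bond further out, the change is ethoxycarbonyl to carboxy. None of the three measured steps touches this part of the molecule: each of them varies only the substituted phenyl on the carbonyl carbon, and the ester is kept throughout compounds 1, 2 and 3. Within the data shown here, there is therefore no measured step that bears on the change from compound 3 to compound 4, and the expectation can rest only on the value of compound 3, with a wide range. The step expected is a number 12.5 percentage points lower from compound 3 to compound 4 (beyond the scatter), that is, no step beyond the scatter is expected in either direction. For compound 4 the estimate in this assay is 60%, with a range from 20% to 85%.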

Compound 4, a percentage reported as inhibition, at one concentration (the size of the read-out at that concentration, not a potency): 98.6%
Compound 4: the middle estimate sits 38.6 percentage points below what was measured, outside the stated range (above it).
By their numbers in this assay, from the lowest: compound 1; then compound 3; then compounds 2 and 4 (each within the scatter of the next).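

In this assay, the ester position is not fixed: hydrogen in place of ethyl on an oxygen next to a carbonyl group gives a number 26.1 percentage points higher from compound 3 to compound 4 (beyond the scatter), so with the 3-chloro-4-fluorophenyl kept, ethoxycarbonyl to carboxy raises the read-out rather than losing it. The earlier steps shown here moved the read-out only through the substituted phenyl on the carbonyl carbon, and this one shows that the number also responds to a change at the other end of the molecule, on the ester itself. Nothing measured here accounts for the size or direction of this step.

On these data alone, whether the carboxy change gives a similar step on other amide partners remains open, notably on the 4-chlorophenyl series, where compound 1, still an ethyl ester, gives 46.9%. Also open is how a methyl ester, a primary carboxamide or a tetrazole would read in place of the carboxy group, and, with a single tested concentration, how any of these compounds would rank by potency.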